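Imidazole series: aryl replaced by carbamoyl at the ring carbon

A few compounds are considered here, and "the series" means these few. Any claim that something is new, unique, unknown or untested is made for them only; others in the source may bear on it.

Compound 1 `Fc1cc(-c2nc(N3CCN(c4ncccc4C(F)(F)F)CC3)[nH]c2-c2ccc(C(F)(F)F)cc2)cc(F)c1F` sets the lowest number in the pair measured so far: in a functional assay on CHO cells for antagonist activity at transient receptor potential cation channel subfamily V member 1 (Rattus norvegicus), read by calcium flux, at pH 5 (a lower number here means a stronger inhibitor, a higher number a weaker inhibitor), compound 1 gives 20 nM. Among the compounds with values here, compound 2 `OCc1cnc(N2CCN(c3nc(-c4ccccc4)c(-c4ccc(C(F)(F)F)cc4)[nH]3)CC2)c(Cl)c1` gives 160 nM in this assay, a higher number than compound 1 that lies beyond the scatter; the two differ in more than one place, so no single step is drawn between them.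

Compound 3 `O=C(NCC1CCCCN1)c1nc(N2CCN(c3ncccc3C(F)(F)F)CC2)[nH]c1-c1ccc(C(F)(F)F)cc1` remains to be measured in this assay. Relative to compound 1 the change is ((piperidin-2-yl)methyl)carbamoyl in place of 3,4,5-trifluorophenyl on an aromatic carbon; an aromatic ring of carbon only leaves, and a non-aromatic ring with a hetero atom, a carbonyl and the donors and acceptors counted above enter at that carbon of the shared core.

Within the data shown here, no measured step of this kind exists in the set, so the size of the step is unknown. The change is large by heavy-atom count and by the counted donors and acceptors, and the expectation is a weaker inhibitor, with a step well beyond the scatter. For compound 3 the expected step is a 20-fold higher number from compound 1 to compound 3 (1.30 log units; beyond the scatter). Compound 3 is therefore estimated at 400 nM, with a range from 80 nM to 3000 nM.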

Compound 3, half-maximal inhibitory concentration: > 4000 nM
Compound 3: no number, only a limit; the forecaster's own chance of this, stated with the estimate: 15%; middle value at least 10-fold (1.00 log units) from the limit.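

Working notes on the ring-carbon position: in this assay compound 3 gives > 4000 nM, which is a limit of the assay and not a number. Within the data shown here, the change of 3,4,5-trifluorophenyl to ((piperidin-2-yl)methyl)carbamoyl, on an aromatic carbon next to the ring atom that bears a 4-(trifluoromethyl)phenyl group, provides the only single-place step in the set and reads as an at least 200-fold higher number from compound 1 to compound 3 (2.30 log units; beyond the scatter), showing that activity at this position is highly sensitive to this exchange even with the rest of compound 1 kept in place. The true size of the step stays bounded on one side only, and it rests on a single value: the limit of > 4000 nM in this assay, at which 1 of the 3 values shown sits.

This one step removes an all-carbon aromatic ring and brings in a carbonyl, the amide hydrogen and a piperidine ring together, and the compounds shown do not tell these parts apart. An unsubstituted carboxamide, an N-benzyl carboxamide or a simple phenyl at this carbon, each on the core of compound 1, would show whether the loss follows the carbonyl link, the piperidine amine or the departure of the aromatic ring.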